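The source may hold more compounds than are shown below. What is called first, only, known or untested is meant among the compounds shown, and "the series" means these compounds.

Working notes on the series. Compound 2 `Nc1sc(-c2ccc(Cl)cc2)c(-c2ccc(Cl)cc2)c1C(=O)NC1CCC(O)CC1` gives 5670 nM in a functional assay on PC-3 cells (Homo sapiens) for inhibition, read by sulforhodamine B assay, with a stated time of 72 h (a higher number here means a weaker inhibitor, a lower number a stronger inhibitor), and compound 1 `Nc1sc(-c2ccc(Cl)cc2)c(-c2ccc(Cl)cc2)c1C(=O)NC1CCC1` gives 24800 nM. For the measured compounds named here, compound 2 therefore stands lowest of the two numbers measured so far; its nearest neighbour is compound 1, separated by a 4.4-fold lower number from compound 1 to compound 2 (0.64 log units; beyond the scatter), which rests on the exchange of cyclobutyl for 4-hydroxycyclohexyl on the amide-type nitrogen.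

Compound 3 `Nc1sc(-c2ccc(Cl)cc2)c(-c2ccc(Cl)cc2)c1C(=O)N1CCNCC1` is not yet measured. Its difference from compound 2 is piperazin-1-yl in place of (4-hydroxycyclohexyl)amino on a carbonyl carbon. Going by the values given here, the only measured step, from compound 1 to compound 2, concerns the same carbonyl substituent, but it swapped one ring on an amide-type nitrogen for another, whereas here the (4-hydroxycyclohexyl)amino group itself leaves and piperazin-1-yl enters on the carbonyl carbon. Among the compounds with values here, no step shows this kind of exchange, so its direction cannot be read from the data. The expectation for compound 3 is a step of a 2.1-fold higher number from compound 2 to compound 3 (0.33 log units; beyond the scatter) in this assay, carried with a wide range. The estimated value for compound 3 in this assay is 12000 nM, expected between 3000 nM and 45000 nM.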

Compound 3, half-maximal inhibitory concentration: 2710 nM
Compound 3: middle estimate off by 4.4-fold (0.65 log units), on the high side, and the stated range ends above it.
By their numbers in this assay, from the lowest: compound 3; then compound 2; then compound 1.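

In this assay the carbonyl carbon accepts a change of the whole amine and not only of the ring on an amide-type nitrogen: piperazin-1-yl in place of (4-hydroxycyclohexyl)amino gives a 2.1-fold lower number from compound 2 to compound 3 (0.32 log units; beyond the scatter) and piperazin-1-yl in place of cyclobutylamino gives a 9.2-fold lower number from compound 1 to compound 3 (0.96 log units; beyond the scatter), which leaves compound 3 with the lowest number of the three. The hydroxyl of compound 2 is therefore not needed for a number below that of compound 1, since compound 3 reaches a lower number with no oxygen in this group and with a ring that holds two nitrogens. Nothing available bears on why the number falls with this change.

From the compounds shown here alone, whether the second ring nitrogen of piperazin-1-yl matters stays open, and morpholin-4-yl, with an oxygen in that place, or 4-methylpiperazin-1-yl on the same carbonyl carbon would address it. Going by these compounds, the two 4-chlorophenyl groups and the free amine are the same in all three compounds, so their contribution also remains unknown.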